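The compounds below may be only part of what the source reports. "The series", "measured", "known", "first", "only" and "open" are said of these compounds alone.

Three compounds sharing one core were tested in a functional assay on A549 cells (Homo sapiens) for antiproliferative activity, read by MTT assay; on this read-out lower numbers stand for stronger inhibition and higher numbers for weaker inhibition. Compound 1 `Cn1c(=O)c(=O)n(C2CCCC2)c2nc(N/N=C/c3ccc(O)c(F)c3)ncc21`, with a 3-fluoro-4-hydroxyphenyl group, gives 97800 nM. Compound 2 `Cn1c(=O)c(=O)n(C2CCCC2)c2nc(N/N=C/c3cccc(Cl)c3Cl)ncc21`, with a 2,3-dichlorophenyl group, gives 39100 nM, and the change is a 2.5-fold lower number from compound 1 to compound 2 (0.40 log units; beyond the scatter). Compound 3 `Cn1c(=O)c(=O)n(C2CCCC2)c2nc(N/N=C/c3ccco3)ncc21`, with a furan-2-yl group, has only a limit, > 100000 nM, and no number.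

Compound 4 `Cc1cc(C)c(/C=N/Nc2ncc3c(n2)n(C2CCCC2)c(=O)c(=O)n3C)c(C)c1` carries 2,4,6-trimethylphenyl in place of furan-2-yl on a carbon with a double bond to nitrogen. For the measured compounds named here, two measured steps bear on this exchange, both with furan-2-yl as the incoming group. One is an at least 2.5-fold higher number from compound 2 to compound 3 (0.40 log units; beyond the scatter), and the other is an at least 1.0-fold higher number from compound 1 to compound 3 (0.00 log units; that floor lies within the scatter), whose floor lies within the scatter. Read in reverse, they suggest that a phenyl group in place of furan-2-yl may lower the number modestly, or may not change it beyond the scatter. The expected step is an at least 1.6-fold lower number from compound 3 to compound 4 (0.22 log units; that floor lies within the scatter). For compound 4 the estimated value is 60000 nM, with an expected range from 25000 nM to 100000 nM.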

Compound 4, half-maximal inhibitory concentration: 12000 nM
Compound 4: the middle estimate sits 5.0-fold (0.70 log units) above what was measured; measured number outside the range, below it.
By their numbers in this assay, from the lowest: compound 4; then compound 2; then compound 1. At a limit, above all of these: compound 3.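

The 2,4,6-trimethylphenyl group gives the strongest inhibition of the set in this assay, with a 3.3-fold lower number from compound 2 to compound 4 (0.51 log units; beyond the scatter) and an 8.2-fold lower number from compound 1 to compound 4 (0.91 log units; beyond the scatter). Against furan-2-yl, the exchange at this carbon with a double bond to nitrogen gives an at least 8.3-fold lower number from compound 3 to compound 4 (0.92 log units; beyond the scatter), a change beyond the scatter that the earlier steps had not settled. Compound 3 has a limit and not a number, so that step is only a floor: the limit of > 100000 nM in this assay, at which 1 of the 4 values shown sits.

As far as these compounds go, whether the lower number comes from the three methyl groups or from the phenyl ring itself stays open. It also remains to be seen what a plain phenyl group, a 4-methylphenyl group or a phenyl ring bearing an amine would give at this position.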